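The compounds below may be only part of what the source reports. "The series", "measured", "known", "first", "only" and "open" are said of these compounds alone.

Compound 3 `O=C(/C=C/c1ccc(OCc2cn(Cc3ccccc3F)nn2)cc1)c1ccc([N+](=O)[O-])cc1` was tested in a functional assay on MIA PaCa-2 cells (Homo sapiens) for inhibition, read by MTT assay, with a stated time of 48 h, tested at 10 uM (on this read-out higher numbers stand for more inhibition of growth at the one concentration tested and lower numbers for less inhibition of growth), where compound 3 gives 22%. Among the compounds with a reported number, compound 3 stands highest: compound 1 `COc1ccc(C(=O)/C=C/c2ccc(OCc3cn(Cc4ccc(F)cc4)nn3)cc2)cc1` gives 6%, a gap beyond the usual scatter. Compound 2 `O=C(/C=C/c1ccc(OCc2cn(Cc3ccccc3)nn2)cc1)c1ccc([N+](=O)[O-])cc1` is reported in this assay as "not active" (no number reported), with no number attached. Compound 4 `O=C(/C=C/c1ccc(OCc2cn(Cc3ccc(F)cc3)nn2)cc1)c1ccc([N+](=O)[O-])cc1` has not been measured yet. It differs from compound 3 by 4-fluorophenyl in place of 2-fluorophenyl on a saturated chain carbon bound to an aromatic nitrogen. Compound 1 also carries a 4-fluorobenzyl group, but its ketone part is different, so it gives no direct comparison. In this assay compound 4 is expected to be somewhat weaker than compound 3, with a step of a number 10 percentage points lower from compound 3 to compound 4 (within the scatter) that may still fall within the scatter. The estimate for compound 4 is 12%, with a range from 0% to 28%.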

Compound 4, percent growth inhibition at one concentration: 44%
Compound 4: the middle estimate sits 32 percentage points below what was measured; the whole stated range lies below it.
By their numbers in this assay, from the lowest: compound 1; then compound 3; then compound 4.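

In this assay, the change from 2-fluorobenzyl to 4-fluorobenzyl gives a number 22 percentage points higher from compound 3 to compound 4 (beyond the scatter) even though the two compounds have the same atoms, so where the fluorine sits on this ring matters. With 4-fluorobenzyl kept, nitro in place of methoxy on an aromatic carbon gives a number 38 percentage points higher from compound 1 to compound 4 (beyond the scatter) and shows that the ketone part matters as well. No measurement available here explains either step. Going by these compounds, it remains open whether chlorine or a methyl group in place of the fluorine would preserve this growth inhibition. An amine in place of the nitro group also remains untested among the compounds shown.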